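Macrocyclic motilin ligands: cyclohexyl to benzothiophenyl side chain

The source may hold more compounds than are shown below. What is called first, only, known or untested is meant among the compounds shown, and "the series" means these compounds.

Compound 1 `CCC[C@@H]1NC(=O)[C@@H](C(C)C)NC(=O)[C@@H](CCCCN)NCCOc2ccccc2/C=C/CNC1=O` reaches only a limit in an assay on isolated protein for displacement of a labelled ligand from Motilin receptor (Homo sapiens) (a higher number here means a weaker inhibitor, a lower number a stronger inhibitor), giving > 10000 nM. Compound 2 `CCC[C@@H]1NC(=O)[C@@H](C(C)C)NC(=O)[C@@H](Cc2ccc(O)cc2)NCCCc2ccccc2CCCNC1=O` likewise stops at a limit in this assay, giving > 10000 nM. Going by the values given here, compound 3 `CCC[C@@H]1NC(=O)[C@@H](C(C)C)NC(=O)[C@@H](CC2CCCCC2)NCCOc2ccccc2CCCNC1=O` is the only member with a measured number in this assay, giving 3250 nM, against the limit of > 10000 nM in this assay, at which 2 of the 3 values shown sit, for the other two. Compound 4 `CCC[C@@H]1NC(=O)[C@@H](C(C)C)NC(=O)[C@@H](Cc2csc3ccccc23)NCCOc2ccccc2CCCNC1=O` differs from it by 1-benzothiophen-3-yl in place of cyclohexyl on a saturated chain carbon bound to a saturated ring carbon. Among the compounds with values here, no step between measured compounds is known, so no size of step can be read from the series. The step of a 1.6-fold lower number from compound 3 to compound 4 (0.21 log units; within the scatter) is expected to stay small, toward a somewhat stronger inhibitor, hardly beyond the scatter. Compound 4 is estimated at 2000 nM, between 500 nM and 8000 nM.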

Compound 4, inhibition constant: 11 nM
Compound 4: the middle estimate sits 180-fold (2.26 log units) above what was measured; measured number below the stated range.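

Replacing cyclohexyl with 1-benzothiophen-3-yl on the shared core gives a 300-fold lower number from compound 3 to compound 4 (2.47 log units; beyond the scatter) in this assay. Until now the series held a single measured number, so no step could be read; this one shows that the group at this position can by itself change the read-out far beyond the scatter. Nothing given here accounts for the size of the step. Open, as far as these compounds go, is whether the gain needs the sulfur or only the two fused aromatic rings. A 1-naphthyl or indol-3-yl group at this position would separate the two.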